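Dichlorophenyl Analogue of a Pair That Shows Only Limits

This account rests on a few compounds, and the source may have more. Where it says the series, first, only, none or still open, it means among the compounds named here.

Measured compounds:
compound 1 `Cc1nc(-c2cccnc2)sc1-c1nnc(Cc2ccccc2)o1` — > 100 ug/mL
compound 2 `Cc1nc(-c2cccnc2)sc1-c1nnc(-c2ccccc2)o1` — > 100 ug/mL

In an ADME assay on HCT-116 cells (Homo sapiens) for cytotoxicity, read by MTT assay (on this read-out higher numbers stand for lower toxicity in this test and lower numbers for higher toxicity in this test), compound 1 gives > 100 ug/mL, which is a limit of the assay and not a number. Compound 2 gives > 100 ug/mL in this assay, again a limit. Going by the values given here, the step that the two limits leave unreadable from compound 1 to compound 2 therefore cannot be sized; the only evidence the pair offers is the limit of > 100 ug/mL in this assay, at which 2 of the 2 values shown sit.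

Compound 3 `Cc1nc(-c2cccnc2)sc1-c1nnc(-c2cccc(Cl)c2Cl)o1` differs from compound 1 by 2,3-dichlorophenyl in place of benzyl on an aromatic carbon. Among the compounds with values here, no measured step with a readable size bears on this change, so no direction can be drawn from the numbers. Within the data shown here, because the sole evidence is the limit of > 100 ug/mL in this assay, at which 2 of the 2 values shown sit, compound 3 is expected to move little, and its step of a number no higher from compound 1 to compound 3 (the limit leaves the size open) is expected to remain within the scatter. In this assay compound 3 is thus estimated at 100 ug/mL, with a range from 40 ug/mL to 250 ug/mL, most probably reported once more as a limit.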

Compound 3, half-maximal cytotoxic concentration: > 100 ug/mL
Compound 3 was reported as a limit (the forecaster's own chance of this, stated with the estimate: 65%); the middle value sits exactly at the limit.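

Going by these compounds alone, compound 3, like compound 1 and compound 2, is reported only as a limit in this assay, so no step among the three can be read: the limit of > 100 ug/mL in this assay, at which 3 of the 3 values shown sit. The compounds shown leave open how these three compare in this assay and at what concentration any of them would reach half-maximal cytotoxicity.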